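The source may report more compounds than this note shows. Statements on the series, on what has been measured and on what is new or still open speak of the compounds shown alone.

In a functional assay on HeLa cells (Homo sapiens) for inhibition; on this read-out higher numbers stand for weaker inhibition of growth and lower numbers for stronger inhibition of growth:
- compound 1 `O=C(OCc1ccccc1)c1ccsc1NC(=O)[C@@H]1CCCN1`: > 250 ug/mL (a limit, not a number)
- compound 2 `O=C(OC1CCCCC1)c1ccsc1NC(=O)[C@@H]1CCCN1`: 92.8 ug/mL

On these data alone, compound 1 has only this limit, (the limit of > 250 ug/mL in this assay, at which 1 of the 2 values shown sits), so its exact position is unknown. Compound 3 `O=C1CC[C@@H](COC(=O)c2ccsc2NC(=O)[C@@H]2CCCN2)N1` has 5-oxopyrrolidin-2-yl in place of phenyl on a saturated chain carbon bound to an oxygen next to a carbonyl group. For the measured compounds named here, the only measured step that changes this same benzyl group is an at least 2.6-fold lower number from compound 1 to compound 2 (0.43 log units; beyond the scatter), and it gives compound 2 a lower number. A similar modest move towards lower numbers in this assay is expected, an at least 1.6-fold lower number from compound 1 to compound 3 (0.22 log units; that floor lies within the scatter). The estimate for compound 3 is 150 ug/mL, with an expected range of 60 ug/mL to 350 ug/mL.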

Compound 3, concentration for 50% growth inhibition: 191 ug/mL
Compound 3: the middle estimate sits 1.3-fold (0.10 log units) below what was measured; the range from low to high includes it.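

In this assay, (5-oxopyrrolidin-2-yl)methyl on an oxygen next to a carbonyl group gives a measured number, while cyclohexyl at the same place keeps the lower one, with a 2.1-fold higher number from compound 2 to compound 3 (0.31 log units; beyond the scatter). Against benzyl, the change is not settled, with an at least 1.3-fold lower number from compound 1 to compound 3 (0.11 log units; that floor lies within the scatter). Compound 1 carries only a limit, not a number: the limit of > 250 ug/mL in this assay, at which 1 of the 3 values shown sits.

Cyclohexyl sits directly on the oxygen, whereas phenyl and 5-oxopyrrolidin-2-yl sit on a saturated chain carbon, so ring type and chain remain unseparated. On these data alone, how cyclohexylmethyl, or an amine or a carboxylic acid on that chain carbon, would read in this assay stays open.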